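Series notes: methoxy for fluoro on the anilide ring

This account rests on a few compounds, and the source may have more. Where it says the series, first, only, none or still open, it means among the compounds named here.

Two compounds of the series have numbers in an in vitro assay on HEK ts201 cells for negative allosteric modulation of Neuronal acetylcholine receptor; alpha3/beta4 (Homo sapiens), read by fluorescence and calcium flux, with a stated time of 1.5 s; on this read-out lower numbers stand for stronger inhibition and higher numbers for weaker inhibition. Compound 1 `COc1ccc(NC(=O)CN2CCN(S(=O)(=O)c3ccc(F)cc3)CC2)cc1` gives 29600 nM, and compound 2 `O=C(CN1CCN(S(=O)(=O)c2ccccc2F)CC1)Nc1ccc(F)cc1` gives 13600 nM. Compound 2 therefore holds the lower of the two numbers, and the gap to compound 1 lies beyond the usual scatter. Among the compounds with values here, compound 1 and compound 2 differ from each other in more than one place, so their two numbers give no single step to read from.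

Compound 3 `COc1ccc(NC(=O)CN2CCN(S(=O)(=O)c3ccccc3F)CC2)cc1` is the next member to be measured in this assay. Relative to compound 2, the change is methoxy in place of fluoro on an aromatic carbon. Compound 1 carries the same methoxy group on the same ring, but its sulfonyl-bearing ring differs as well, so that pair does not isolate the change.

Within the data shown here, with no measured step for this exact change, a modest step in the direction of a higher number is expected for compound 3 in this assay, which may still fall within the scatter. Compound 3 is expected at 20000 nM, with a range from 8000 nM to 50000 nM. The expected step of a 1.5-fold higher number from compound 2 to compound 3 (0.17 log units; within the scatter) is an estimate only.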

Compound 3, half-maximal inhibitory concentration: 19100 nM
The estimate for compound 3 lay 1.0-fold (0.02 log units) above the measured number; low and high end bracket the measured number.
By their numbers in this assay, from the lowest: compounds 2, 3 and 1 (each within the scatter of the next, the first and the last beyond it).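

In this assay the exchange of 4-fluorophenyl to 4-methoxyphenyl, on an aromatic carbon para to a large group, now has a measured step of a 1.4-fold higher number from compound 2 to compound 3 (0.15 log units; within the scatter) and so does not separate the two compounds at this position, a reading that the earlier pair, differing in more than one place, could not give. Within the data shown here, compound 3 also provides the first single-place reading on the other side of the shared core, where 2-fluorophenyl in place of 4-fluorophenyl on a sulfonyl sulfur gives a 1.5-fold lower number from compound 1 to compound 3 (0.19 log units; within the scatter) and likewise does not separate the pair. No measurement is available that bears on the origin of either result.

On these data alone, whether the methoxy-for-fluoro step keeps this size when 4-fluorophenyl sits on the sulfonyl sulfur remains open, since these compounds give that change only with 2-fluorophenyl there. Also open, as far as these compounds go, is whether a hydroxyl, an amine, a carboxylic acid or a longer ether chain such as ethoxy at this aromatic carbon would give a step beyond the scatter in this assay.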